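Adding a methyl to the ethyl of compound 3

The compounds below may be only part of what the source reports. "The series", "measured", "known", "first", "only" and "open" are said of these compounds alone.

Compound 1 `C/N=C(\S)[C@]1(c2cccc(C(F)(F)F)c2)CCCC[S+]1[O-]`: 800 nM
Compound 2 `C/N=C(\S)[C@]1(c2cccc(F)c2)CCCC[S+]1[O-]`: 7000 nM
Compound 3 `CC/N=C(\S)[C@]1(c2cccnc2)CCCC[S+]1[O-]`: 300 nM

All three values come from a functional assay (aorta) for inhibition, with Rattus norvegicus as the target; on this read-out lower numbers stand for stronger inhibition and higher numbers for weaker inhibition. Compound 3 has the lowest number of the three, and its gaps to compound 1 and compound 2 are beyond the scatter.

Compound 4 `CC(C)/N=C(\S)[C@]1(c2cccnc2)CCCC[S+]1[O-]` is the next to be measured. It differs from compound 3 by methyl in place of hydrogen on a saturated chain carbon bound to a double-bonded nitrogen and a saturated chain carbon, or ethyl to isopropyl.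

Among the measured compounds shown here, no measured step covers this change. The only one available, an 8.8-fold higher number from compound 1 to compound 2 (0.94 log units; beyond the scatter), is fluoro in place of trifluoromethyl on an aromatic carbon, so it gives a rough scale and no direction. A step no larger than that one is expected in this assay. A higher number seems likelier, as compound 3 already stands lowest at 300 nM.

The expected change is a 3.0-fold higher number from compound 3 to compound 4 (0.48 log units; beyond the scatter). The estimated value for compound 4 is 900 nM, with an expected range of 250 nM to 3000 nM.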

Compound 4, concentration for 90% inhibition: 10000 nM
The estimate for compound 4 lay 11-fold (1.05 log units) below the measured number; measured number above the stated range.
By their numbers in this assay, from the lowest: compound 3; then compound 1; then compounds 2 and 4 (each within the scatter of the next).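

In this assay, this place on the chain is sensitive to a small change: ethyl to isopropyl, with one added methyl, gives a 33-fold higher number from compound 3 to compound 4 (1.52 log units; beyond the scatter). Among the compounds shown here, this is the first step read at this place, and it is larger than the only earlier step, the aromatic change an 8.8-fold higher number from compound 1 to compound 2 (0.94 log units; beyond the scatter). Nothing available gives a reason for the size of the step.

As far as these compounds go, whether a straight propyl chain or a cyclopropyl group at this place would match ethyl or isopropyl remains open, so unbranched and branched chains cannot yet be separated. From the compounds shown here alone, compounds 1 and 2 carry methyl at this place but differ from compound 3 in more than one place, so the effect of a chain shorter than ethyl on the shared core also remains open.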